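Shortening the Ester Tail of a Sigma-1 Ligand

This account rests on a few compounds, and the source may have more. Where it says the series, first, only, none or still open, it means among the compounds named here.

Compound 1, with the structure `O=C(CCCc1ccccc1)OC(CCN1CCN(CCCN(c2ccc(F)cc2)c2ccc(F)cc2)CC1)c1ccccc1`, was tested in an assay on membranes from brain for displacement of a labelled ligand from Sigma non-opioid intracellular receptor 1 (Cavia porcellus) (a higher number here means a weaker inhibitor, a lower number a stronger inhibitor), and gives 246 nM. This is the highest of the three numbers recorded so far. Compound 2, with the structure `C=CC(=O)O[C@@H](Cc1ccccc1)CN1CCN(CCCN(c2ccc(F)cc2)c2ccc(F)cc2)CC1`, gives 45.5 nM in this assay, and compound 3, with the structure `O[C@H](Cc1ccccc1)CN1CCN(CCCN(c2ccc(F)cc2)c2ccc(F)cc2)CC1`, gives 33.4 nM. Both of these sit on a different arrangement of the shared core, so their numbers only show where compound 1 stands: above them, by a margin that in each case goes beyond the usual scatter of repeated measurements.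

The next compound to be measured is compound 4, with the structure `CC(=O)OC(CCN1CCN(CCCN(c2ccc(F)cc2)c2ccc(F)cc2)CC1)c1ccccc1`. It differs from compound 1 in a single place: hydrogen in place of phenethyl on a saturated chain carbon bound to a carbonyl carbon. The ester that hangs on the carbon bearing the phenyl and the chain is thus cut back to its smallest form, an acetoxy group, while everything else in compound 1 stays as it is.

Among the measured compounds shown here, no measured pair in this set isolates exactly this change, so the size of the step has to be guessed. The expectation is a step of a 1.6-fold lower number from compound 1 to compound 4 (0.21 log units; within the scatter) that is small and points toward a lower number, since the smaller esters and the free alcohol seen in compound 2 and compound 3 carry the lower values. Compound 4 is therefore estimated at 150 nM, with a plausible range from 50 nM to 500 nM.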

Compound 4, inhibition constant: 56.6 nM
Estimate against measurement, compound 4: 2.7-fold (0.42 log units) above; low and high end bracket the measured number.
By their numbers in this assay, from the lowest: compounds 3, 2 and 4 (each within the scatter of the next); then compound 1.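

Among the compounds shown here, the first direct reading of this position in this assay comes with the cut from ((3-phenylpropyl)carbonyl)oxy to acetoxy: a 4.3-fold lower number from compound 1 to compound 4 (0.64 log units; beyond the scatter), a step too large to put down to scatter. On the core of compound 1, then, the phenethyl on a saturated chain carbon bound to a carbonyl carbon is not needed for binding, and taking it away goes with the lower number. The shortened ester also brings this series into the range of the other arrangement of the core, with a 1.7-fold higher number from compound 3 to compound 4 (0.23 log units; within the scatter), a gap that lies within the scatter. No separate measurement bears on the reason for the step.

On these data alone, only the two ends of this tail are seen, phenethyl and hydrogen, so it remains open how the number moves with a tail of middling length, such as a methyl or a benzyl group at this place. Also open, as far as these compounds go, is what happens on the same core when the acetoxy gives way to a free hydroxyl group, or when the ester is replaced by an amide.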